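From a Limit Value to a Phenethyl Side Chain

A few compounds are considered here, and "the series" means these few. Any claim that something is new, unique, unknown or untested is made for them only; others in the source may bear on it.

Of the compounds shown here, three that share one core have been tested in a toxicity assay on GES1 cells (Homo sapiens) for inhibition, read by MTT assay, with a stated time of 72 h; a higher number here means a weaker inhibitor, a lower number a stronger inhibitor. There, compound 1 `Cc1cc(N2CC[C@@H](C)[C@@H](N(C)c3ncnc4[nH]ccc34)C2)n2nc(SCc3ccccc3)nc2n1` gives 67200 nM, and compound 2 `Cc1cc(N2CC[C@@H](C)[C@@H](N(C)c3ncnc4[nH]ccc34)C2)n2nc(SCC3CC3)nc2n1` gives 27900 nM.

Compound 3 `Cc1cc(N2CC[C@@H](C)[C@@H](N(C)c3ncnc4[nH]ccc34)C2)n2nc(SCc3csc4ccc(Cl)cc34)nc2n1` gives only a limit, > 100000 nM, and not an exact number. Its true position is therefore open, although the measurements show an at least 3.5-fold higher number from compound 2 to compound 3 (0.55 log units; beyond the scatter). The comparison with the other measured compound is less firm, showing an at least 1.4-fold higher number from compound 1 to compound 3 (0.17 log units; that floor lies within the scatter).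

Compound 4 `Cc1cc(N2CC[C@@H](C)[C@@H](N(C)c3ncnc4[nH]ccc34)C2)n2nc(SCCc3ccccc3)nc2n1` differs from it at one place, on a saturated chain carbon bound to a sulfur, with benzyl in place of 5-chloro-1-benzothiophen-3-yl (benzyl in place of 5-chloro-1-benzothiophen-3-yl on a saturated chain carbon bound to a sulfur). Within the data shown here, all the measured steps involve changes at this same place. The third of them, with cyclopropyl in place of phenyl, shows a 2.4-fold lower number from compound 1 to compound 2 (0.38 log units; beyond the scatter).

The closest measured relative of compound 4 is compound 1 at 67200 nM, since it also has a phenyl group in this side chain. A value near that of compound 1 therefore seems likely, so the expected change is an at least 1.6-fold lower number from compound 3 to compound 4 (0.22 log units; that floor lies within the scatter). For compound 4 the estimated value is 60000 nM, with an expected range of 25000 nM to 100000 nM.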

Compound 4, half-maximal inhibitory concentration: 66200 nM
Compound 4: the middle estimate sits 1.1-fold (0.04 log units) below what was measured; the measured number falls inside the stated range.
By their numbers in this assay, from the lowest: compound 2; then compounds 4 and 1 (each within the scatter of the next). At a limit, above all of these: compound 3.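

Placing benzyl rather than phenyl on the saturated chain carbon bound to a sulfur leaves no readable change in this assay, with a 1.0-fold lower number from compound 1 to compound 4 (0.01 log units; within the scatter) as the step, so the phenethyl side chain of compound 4 and the benzyl side chain of compound 1 cannot be told apart here. The separation from the cyclopropyl side chain also holds for this longer chain, as benzyl in place of cyclopropyl gives a 2.4-fold higher number from compound 2 to compound 4 (0.38 log units; beyond the scatter), a step of modest size. Compound 3 gives only a limit, so an at least 1.5-fold lower number from compound 3 to compound 4 (0.17 log units; that floor lies within the scatter) is a floor that sets no firm order for this pair: the limit of > 100000 nM in this assay, at which 1 of the 4 values shown sits.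

The compounds shown leave open whether a still longer chain, such as phenylpropyl, would stay level with compound 1 and compound 4 in this assay or would shift as far as the cyclopropyl side chain of compound 2 does. Also open, as far as these compounds go, is how an amine or a carboxylic acid on this side chain, in place of the phenyl ring, would read in the same assay.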